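The source may report more compounds than this note shows. Statements on the series, on what has been measured and on what is new or still open speak of the compounds shown alone.

Compound 1 `COc1cc(OC)c2c(=O)cc(C(=O)Nc3ccc(C4CCCCC4)cc3)[nH]c2c1` gives > 43100 nM in a functional assay on SUP-B15 cells (Homo sapiens) for antiproliferative activity, with a stated time of 72 h (on this read-out higher numbers stand for an effect only at larger amounts of compound and lower numbers for an effect already at smaller amounts), which is a limit of the assay.
Compound 2 `COc1cc(OC)c2c(=O)cc(C(=O)Nc3ccc(Oc4ccc(F)cc4)cc3)[nH]c2c1` gives > 50000 nM in this assay, which is likewise a limit.

Because both values are limits, as the limit of > 43100 nM in this assay, at which 1 of the 2 values shown sits, and the limit of > 50000 nM in this assay, at which 1 of the 2 values shown sits, show, the step that the two limits leave unreadable from compound 1 to compound 2 cannot be read in size or direction. On the numbers shown, compound 2 therefore stands only at a limit of this assay, with no number of its own, and nothing separates it from compound 1.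

Compound 3 `COc1cc(OC)c2c(=O)cc(C(=O)Nc3ccc(S(=O)(=O)c4ccccc4)cc3)[nH]c2c1` differs from compound 2 by phenylsulfonyl in place of 4-fluorophenoxy on an aromatic carbon. Within the data shown here, the one measured step touches the same aromatic carbon but is unreadable, so it offers no size and no direction, and no shift beyond the scatter can be expected from it.

Compound 3 is accordingly expected to give 50000 nM in this assay, with a range from 20000 nM to 100000 nM. The expected step is a number no higher from compound 2 to compound 3 (the limit leaves the size open), and most likely this assay will again report only a limit.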

Compound 3, half-maximal effective concentration: > 70600 nM
Compound 3: no number, only a limit (the forecaster's own chance of this, stated with the estimate: 75%); at least 1.4-fold (0.14 log units) between middle value and limit.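

Compound 3, like compound 1 and compound 2, stands only at a limit of this assay, and the steps from compound 1 and compound 2 to compound 3 cannot be read. The compounds shown leave open whether any of these three groups allows a measurable effect in this assay.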